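This account rests on a few compounds, and the source may have more. Where it says the series, first, only, none or still open, it means among the compounds named here.

Series notes. Compound 3 `Nc1scc(CN2CCN(c3cccc(F)c3F)CC2)c1C(=O)c1ccc(Cl)cc1` sits level with compound 2 `Nc1scc(CN2CCN(c3ccc(F)c(F)c3)CC2)c1C(=O)c1ccc(Cl)cc1` at the digits shown, the two together the lowest of three numbers; in an assay on CHO cells for displacement of a labelled ligand from adenosine receptor A1 (Homo sapiens), read by scintillation counting, with a stated time of 120 min, tested at 10 uM (on this read-out higher numbers stand for more inhibition at the one concentration tested (going by the name of the read-out) and lower numbers for less inhibition), compound 3 gives 0% and compound 2 gives 0%, while compound 1 `Nc1scc(CN2CCN(c3ccc([N+](=O)[O-])cc3)CC2)c1C(=O)c1ccc(Cl)cc1` gives 1%. All three changes so far swap the group on the amine nitrogen in a ring: a number 1 percentage points lower from compound 1 to compound 2 (within the scatter), a number 1 percentage points lower from compound 1 to compound 3 (within the scatter) and no change at the digits printed from compound 2 to compound 3 (within the scatter), each within the scatter. Compound 4 `Nc1scc(CN2CCN(c3cccc(Cl)c3)CC2)c1C(=O)c1ccc(Cl)cc1` changes the same place: 3-chlorophenyl in place of 2,3-difluorophenyl on an amine nitrogen in a ring. Every step seen at this place has been flat, so no shift beyond the scatter is expected, the estimated step being a number 1 percentage points higher from compound 3 to compound 4 (within the scatter). Compound 4 is therefore expected to give about 1%, with a range from -5% to 10%.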

Compound 4, a percentage reported as inhibition, at one concentration (the size of the read-out at that concentration, not a potency): 0%
Compound 4: middle estimate off by 1 percentage points, on the high side; the range from low to high includes it.
By their numbers in this assay, from the lowest: compounds 2, 3, 4 and 1 (each within the scatter of the next).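

In this assay, a phenyl carrying one chlorine reads like the phenyls carrying two fluorines, with (no change at the digits printed from compound 3 to compound 4 (within the scatter)) and (no change at the digits printed from compound 2 to compound 4 (within the scatter)). It also stays within the scatter of the 4-nitrophenyl group (a number 1 percentage points lower from compound 1 to compound 4 (within the scatter)), so the flat picture on this amine nitrogen now covers chlorine as well as fluorine and nitro substituents. Nothing available accounts for this flatness.

With every reading this close at one concentration, these groups cannot be ranked. As far as these compounds go, whether a phenyl bearing an amine or a carboxylic acid, or a plain alkyl chain in place of the phenyl, would lift the number stays open.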